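A few compounds are considered here, and "the series" means these few. Any claim that something is new, unique, unknown or untested is made for them only; others in the source may bear on it.

Measured so far:
compound 1, `CNC(=O)[C@@]12C[C@@H]1[C@@H](n1cnc3c(C)nc(C#Cc4ccccc4)nc31)[C@H](O)[C@@H]2O`, 15%
compound 2, `CNC(=O)[C@@]12C[C@@H]1[C@@H](n1cnc3c(/C=C(\O)c4ccccc4)nc(Cl)nc31)[C@H](O)[C@@H]2O`, 30%

Of the compounds shown here, two have been measured in an assay on CHO cells for displacement of a labelled ligand from adenosine receptor A1 (Homo sapiens), read by scintillation counting, with a stated time of 60 min, tested at 10 uM; a higher number here means more inhibition at the concentration tested (going by the name of the read-out), a lower number less inhibition. Compound 1 gives 15%, while compound 2 gives 30%. Compound 2 therefore stands highest of the two numbers, and its nearest neighbour, compound 1, lies a step lower that goes beyond the usual scatter. The next compound, compound 3, has the structure `CNC(=O)[C@@]12C[C@@H]1[C@@H](n1cnc3c(/C=C(\O)c4ccccc4)nc(C#Cc4ccccc4)nc31)[C@H](O)[C@@H]2O`. It differs from compound 2 in one place: 2-phenylethynyl in place of chloro on an aromatic carbon. Among the compounds with values here, no step between two measured compounds matches this exchange, so its size cannot be read off the data; compound 1 carries the same 2-phenylethynyl group, but with other changes elsewhere, and it sits lower than compound 2. Given that, a modest step downward or none beyond the scatter is expected for the change from compound 2 to compound 3 in this assay, estimated at a number 6 percentage points lower from compound 2 to compound 3 (within the scatter). Compound 3 is expected to give about 24%, within a range from 5% to 50%.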

Compound 3, a percentage reported as inhibition, at one concentration (the size of the read-out at that concentration, not a potency): 16%
For compound 3 the middle estimate is 8 percentage points above the measured one; the range from low to high includes it.
By their numbers in this assay, from the lowest: compounds 1 and 3 (each within the scatter of the next); then compound 2.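

In this assay, within the data shown here, 2-phenylethynyl in place of chloro on the aromatic carbon between two ring nitrogen atoms gives a number 14 percentage points lower from compound 2 to compound 3 (beyond the scatter) and so provides the first direct reading of this exchange, with the rest of the molecule held constant. With 2-phenylethynyl fixed at that carbon, 2-hydroxy-2-phenylethenyl in place of methyl on an aromatic carbon gives a number 1 percentage points higher from compound 1 to compound 3 (within the scatter) and so does not separate this pair. Nothing available accounts for either result.

The compounds shown leave open how an amine or a plain ethynyl group at the carbon between the two ring nitrogen atoms would compare with chloro in this assay. They also leave open whether the exchange of chloro for 2-phenylethynyl would give a similar step with methyl in place of 2-hydroxy-2-phenylethenyl.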